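Working notes: from compound 3 to compound 4

The compounds below may be only part of what the source reports. "The series", "measured", "known", "first", "only" and "open" are said of these compounds alone.

Measured so far in an assay on CHO cells for antagonist activity at transient receptor potential cation channel subfamily V member 1 (Homo sapiens), read by FLIPR; on this read-out higher numbers stand for weaker inhibition and lower numbers for stronger inhibition:
- compound 1 `CC1CCN(c2nc(C(F)(F)Cl)ccc2CNC(=O)C(C)c2ccc(NS(C)(=O)=O)c(F)c2)CC1`: 0.3 nM
- compound 2 `CC1CCN(c2nc(C3CC3)ccc2CNC(=O)C(C)c2ccc(NS(C)(=O)=O)c(F)c2)CC1`: 0.9 nM
- compound 3 `CC(C(=O)NCc1ccc(C(F)(F)Cl)nc1N1CCCCC1)c1ccc(NS(C)(=O)=O)c(F)c1`: 1.3 nM

Compound 3 has the highest of the three numbers. Its gap to compound 2 lies within the scatter, so the two are not separated. For the measured compounds named here, the gap to compound 1 is real: a 4.3-fold higher number from compound 1 to compound 3 (0.64 log units; beyond the scatter), the only change there being hydrogen in place of methyl on a saturated ring carbon.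

Compound 4 `CC(C(=O)NCc1ccc(C2CC2)nc1N1CCCCC1)c1ccc(NS(C)(=O)=O)c(F)c1` is compound 3 with one change: cyclopropyl in place of chloro(difluoro)methyl on an aromatic carbon.

The same replacement has been made once before, on compound 1, giving compound 2: a 3.0-fold higher number from compound 1 to compound 2 (0.48 log units; beyond the scatter). Going by the values given here, that is the only measured step that bears on the present one. It lies beyond the scatter and is modest in size. Carrying it over to compound 3, a step of similar size toward a higher number is expected for compound 4, and the step of a 3.0-fold higher number from compound 3 to compound 4 (0.48 log units; beyond the scatter) is the estimate that follows from the measured step of a 3.0-fold higher number from compound 1 to compound 2 (0.48 log units; beyond the scatter). On that basis compound 4 is expected to give 3.9 nM, with a range from 1.5 nM to 10 nM.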

Compound 4, inhibition constant: 1.1 nM
Beside the measured number, compound 4's estimate is 3.5-fold (0.55 log units) above it, and the stated range ends above it.
By their numbers in this assay, from the lowest: compound 1; then compounds 2, 4 and 3 (each within the scatter of the next).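

In this assay, cyclopropyl in place of chloro(difluoro)methyl at this position, next to the ring nitrogen, gives no separable change on the core of compound 3, with a 1.2-fold lower number from compound 3 to compound 4 (0.07 log units; within the scatter), so the size of this change depends on the core that carries it: the same change on two cores in this assay, a 3.0-fold higher number (0.48 log units; beyond the scatter) from compound 1 to compound 2 and a 1.2-fold lower number (0.07 log units; within the scatter) from compound 3 to compound 4, 3.5-fold (0.55 log units) apart, beyond the scatter of two such steps

The reverse reading holds for hydrogen in place of methyl on the saturated ring carbon, which gives a 1.2-fold higher number from compound 2 to compound 4 (0.09 log units; within the scatter) when cyclopropyl is present, so in these four compounds the two changes do not add up: the same change on two cores in this assay, a 4.3-fold higher number (0.64 log units; beyond the scatter) from compound 1 to compound 3 and a 1.2-fold higher number (0.09 log units; within the scatter) from compound 2 to compound 4, 3.5-fold (0.55 log units) apart, beyond the scatter of two such steps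

Compound 1, at 0.3 nM, is the only one of the four that holds both the methyl and the chloro(difluoro)methyl, while compounds 2, 3 and 4 are not separated from each other.

Only two groups are shown at the aromatic position and two at the saturated ring carbon, so it stays open whether this dependence extends to other pairs. A trifluoromethyl or methoxy group on the aromatic carbon, combined with an ethyl group on the saturated ring carbon, would test it.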